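Triarylethylene amides: pyrrolidinyl urea to benzyl oxamide

This account rests on a few compounds, and the source may have more. Where it says the series, first, only, none or still open, it means among the compounds named here.

Compound 1 `CCOC(=O)C(=O)NCC/C(=C(\c1ccccc1)c1ccc(OC)cc1)c1ccccc1`: > 50000 nM
Compound 2 `COc1ccc(/C(=C(/CCNC(=O)N2CCCC2)c2ccccc2)c2ccccc2)cc1`: > 50000 nM

In a functional assay on MDA-MB-231 cells (Homo sapiens) for cytotoxicity, read by MTT assay, with a stated time of 72 h (a higher number here means a weaker inhibitor, a lower number a stronger inhibitor), compound 1 gives only a limit, > 50000 nM. Compound 2 also gives only a limit in this assay, > 50000 nM. The step that the two limits leave unreadable from compound 1 to compound 2 is unreadable in size and direction, since both values sit at the limit of > 50000 nM in this assay, at which 2 of the 2 values shown sit. Compound 3 `COc1ccc(/C(=C(/CCNC(=O)C(=O)NCc2ccccc2)c2ccccc2)c2ccccc2)cc1` carries benzylcarbamoyl in place of pyrrolidin-1-yl on a carbonyl carbon. Going by the values given here, no measured step gives a readable size, so nothing beyond the scatter is expected; the estimated step that the limit leaves unreadable from compound 2 to compound 3 is expected to be small. Compound 3 is expected at 60000 nM, range 20000 nM to 200000 nM, most likely reported again as a limit.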

Compound 3, half-maximal inhibitory concentration: 11500 nM
For compound 3 the middle estimate is 5.2-fold (0.72 log units) above the measured one; the measured number lies below the stated range.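

Going by these compounds alone, compound 3 gives the first value in this assay that is a number and not a limit, so changes on this carbonyl carbon can now be read. Benzylcarbamoyl in place of pyrrolidin-1-yl gives an at least 4.3-fold lower number from compound 2 to compound 3 (0.63 log units; beyond the scatter), and benzylamino in place of ethoxy gives an at least 4.3-fold lower number from compound 1 to compound 3 (0.63 log units; beyond the scatter). The full size of both steps stays unreadable, as each starts from a limit: the limit of > 50000 nM in this assay, at which 2 of the 3 values shown sit.

From the compounds shown here alone, whether the six-membered aromatic ring or the amide hydrogen of the benzylcarbamoyl group goes with the lower number remains open. So does the outcome with a phenethylamino group or a carboxylic acid on this carbonyl carbon.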